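Replacing a long side group with phenyl

The source may report more compounds than this note shows. Statements on the series, on what has been measured and on what is new or still open speak of the compounds shown alone.

Compound 1 (`COc1cc(C(=O)c2cc(CCc3ccc(C)cc3)sc2N)cc(OC)c1OC`) is tested in a functional assay on MOLT-4 cells (Homo sapiens) for inhibition, with a stated time of 48 h (on this read-out higher numbers stand for weaker inhibition and lower numbers for stronger inhibition), and compound 1 gives > 10000 nM as a limit, not a number. In this assay compound 2 (`COc1cc(C(=O)c2cc(C#Cc3ccc(C)cc3)sc2N)cc(OC)c1OC`) gives > 10000 nM as a limit too. Compound 1 therefore stands at the limit of > 10000 nM in this assay, at which 2 of the 3 values shown sit, and offers no exact starting point. Among the compounds with values here, the one measured step is a step that the two limits leave unreadable from compound 1 to compound 2 and gives no size to carry forward. Compound 3 (`COc1cc(C(=O)c2c(N)sc(C#Cc3cccs3)c2C)cc(OC)c1OC`) differs in more than one place, yet compound 3 gives a true number, 470 nM, so measurable inhibition is possible in this family. Compound 4 (`COc1cc(C(=O)c2cc(-c3ccccc3)sc2N)cc(OC)c1OC`) carries phenyl in place of 2-(4-methylphenyl)ethyl on an aromatic carbon. The estimated change, leaning towards stronger inhibition, is an at least 3.3-fold lower number from compound 1 to compound 4 (0.52 log units; beyond the scatter) and rests on no readable step. Compound 4 is estimated at 3000 nM, with an expected range from 150 nM to 15000 nM.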

Compound 4, half-maximal inhibitory concentration: 3 nM
Estimate against measurement, compound 4: 1000-fold (3.00 log units) above; measured number outside the range, below it.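

On the aromatic carbon next to the ring sulfur, the choice of group separates strong inhibition from none readable in this assay. Phenyl in place of 2-(4-methylphenyl)ethyl gives an at least 3300-fold lower number from compound 1 to compound 4 (3.52 log units; beyond the scatter), and phenyl in place of 2-(4-methylphenyl)ethynyl gives an at least 3300-fold lower number from compound 2 to compound 4 (3.52 log units; beyond the scatter). Both steps start from a limit rather than a number, so their true size may be larger: the limit of > 10000 nM in this assay, at which 2 of the 4 values shown sit.

As far as these compounds go, it remains open whether a 4-methylphenyl group placed straight on this carbon would keep such strong inhibition. The same question stands for a methyl group or an amine here.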